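A few compounds are considered here, and "the series" means these few. Any claim that something is new, unique, unknown or untested is made for them only; others in the source may bear on it.

Measured in a functional assay on OVCAR-8 cells (Homo sapiens) for inhibition, read by colorimetric assay and sulforhodamine B assay, with a stated time of 48 h; on this read-out higher numbers stand for weaker inhibition of growth and lower numbers for stronger inhibition of growth:
- compound 1 `CCCCCCCCCCCC[C@@H](O)[C@H]1CC[C@H]([C@H](O)CCCCCCCCCCNC(=O)c2cccs2)O1`: 3020 nM
- compound 2 `CCCCCCCCCCCC[C@@H](O)[C@H]1CC[C@H]([C@H](O)CCCCCCCCCCNC(=O)c2ccco2)O1`: 100000 nM

Compound 2 has the higher of the two numbers, so it is the weaker growth inhibitor of the pair. The next compound, compound 3 `CCCCCCCCCCCC[C@@H](O)[C@H]1CC[C@H]([C@H](O)CCCCCCCCCCNC(=O)c2ccoc2)O1`, has the same atoms as compound 2, joined differently: furan-3-yl in place of furan-2-yl on a carbonyl carbon. In plain terms, it carries furan-3-yl in place of furan-2-yl on a carbonyl carbon.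

For the measured compounds named here, only one measured step bears on this change: a 33-fold higher number from compound 1 to compound 2 (1.52 log units; beyond the scatter). This large step, made at the same carbonyl carbon, shows that the ring placed there can matter a great deal in this assay. However, it swaps thiophen-2-yl for furan-2-yl, and no measurement yet compares the two furans directly. The direction is therefore uncertain, but with compound 2 at 100000 nM, a lower number seems the more likely outcome. The expected change is moderate, an estimated 4.0-fold lower number from compound 2 to compound 3 (0.60 log units; beyond the scatter). For compound 3 the estimated value is 25000 nM, with an expected range of 4000 nM to 100000 nM.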

Compound 3, concentration for 50% growth inhibition: 66100 nM
Compound 3: middle estimate off by 2.6-fold (0.42 log units), on the low side; the range from low to high includes it.
By their numbers in this assay, from the lowest: compound 1; then compounds 3 and 2 (each within the scatter of the next).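

In this assay the furan ring can be attached to the carbonyl carbon in either way, and the change from furan-2-yl to furan-3-yl gives a 1.5-fold lower number from compound 2 to compound 3 (0.18 log units; within the scatter) and so leaves the two furans indistinguishable on this read-out. The thiophen-2-yl group of compound 1 also stands well apart from the new isomer, with a 22-fold higher number from compound 1 to compound 3 (1.34 log units; beyond the scatter) in this assay, so among these three compounds the large gap follows the exchange of thiophene for furan at this carbonyl carbon, whichever way the furan is attached. Nothing available explains why the thiophene and the two furans differ so widely.

The compounds shown leave open whether thiophen-3-yl would stay close to thiophen-2-yl or drop to the level of the furans, and whether a plain phenyl ring on the same carbonyl carbon would keep the level of compound 1. They also do not tell whether a shorter chain in place of the one carrying the amide would change how much the choice of ring matters.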